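Replacing 1-methylpyrrolidin-3-yl with 1-(oxetan-3-yl)pyrrolidin-3-yl

A few compounds are considered here, and "the series" means these few. Any claim that something is new, unique, unknown or untested is made for them only; others in the source may bear on it.

Measured so far in an ADME assay on microsomes from liver (Homo sapiens) for metabolic stability; a higher number here means faster removal of the compound, a lower number slower removal (both values are limits)
- compound 1 `Cc1cc2ncccc2cc1Nc1ncc2c(n1)n(C1CCN(C)CC1)c(=O)n2C` gives < 4 mL.min-1.g-1 (a limit)
- compound 2 `Cc1cc2ncccc2cc1Nc1ncc2c(n1)n([C@@H]1CCN(C)C1)c(=O)n2C` gives < 4 mL.min-1.g-1 (a limit)

Compound 2 gives < 4 mL.min-1.g-1 in this assay and this is a limit of the assay, not a number. Compound 3 `Cc1cc2ncccc2cc1Nc1ncc2c(n1)n([C@H]1CCN(C3COC3)C1)c(=O)n2C` carries 1-(oxetan-3-yl)pyrrolidin-3-yl in place of 1-methylpyrrolidin-3-yl on an aromatic nitrogen. Within the data shown here, the one measured step that bears on this change is a step that the two limits leave unreadable from compound 1 to compound 2 and it offers no size to carry over. Both values share one limit (the limit of < 4 mL.min-1.g-1 in this assay, at which 2 of the 2 values shown sit) and so neither a size nor a direction can be read from them. No step beyond the scatter is therefore expected, and the expected change is a number no lower from compound 2 to compound 3 (the limit leaves the size open) as an estimate. The estimate for compound 3 is 4 mL.min-1.g-1 with an expected range from 2 mL.min-1.g-1 to 10 mL.min-1.g-1 and the assay may again report only a limit.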

Compound 3, intrinsic clearance in microsomes: 33 mL.min-1.g-1
The estimate for compound 3 lay 8.3-fold (0.92 log units) below the measured number; measured number above the stated range.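

The step between compound 1 and compound 2 cannot be read in this assay, because both values sit at one limit of the assay: the limit of < 4 mL.min-1.g-1 in this assay, at which 2 of the 3 values shown sit.

Among these compounds, compound 3 gives the first readable number. 1-(oxetan-3-yl)pyrrolidin-3-yl in place of 1-methylpyrrolidin-3-yl gives an at least 8.2-fold higher number from compound 2 to compound 3 (0.91 log units; beyond the scatter), and in place of 1-methylpiperidin-4-yl it gives an at least 8.2-fold higher number from compound 1 to compound 3 (0.91 log units; beyond the scatter). The number in this assay is therefore not set by the shared core alone: it moves with the group on this aromatic nitrogen.

From the compounds shown here alone, whether the step belongs to the oxetan-3-yl group itself or would follow any larger group in that place stays open, and a 1-cyclobutylpyrrolidin-3-yl group would help separate the two. Going by these compounds, each step also rests on a limit, so its full size remains unknown.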